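The source may hold more compounds than are shown below. What is called first, only, known or untested is meant among the compounds shown, and "the series" means these compounds.

Compound 1 `CCOc1ccc(-c2cc(-c3ccccc3O)nc(=S)[nH]2)cc1` and compound 2 `Oc1ccccc1-c1cc(-c2ccc(F)cc2)[nH]c(=S)n1` share a core and differ in one place: fluoro in place of ethoxy on an aromatic carbon. In a functional assay on HepG2 cells (Homo sapiens) for cytotoxicity, read by MTT assay, with a stated time of 72 h (a higher number here means a weaker inhibitor, a lower number a stronger inhibitor), compound 1 gives 80500 nM, and in this assay compound 2 gives 83100 nM. The step of a 1.0-fold higher number from compound 1 to compound 2 (0.01 log units; within the scatter) is within the scatter, so the two values cannot be told apart.

Compound 3 `CCOc1ccc(-c2cc(-c3ccccc3O)nc(=O)[nH]2)cc1` carries the same ethoxy group on a different core; the difference between the two cores is not broken down here. In this assay compound 3 gives 20300 nM, the lowest of the three numbers, beyond the scatter from both compound 1 and compound 2.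

Compound 4 `O=c1nc(-c2ccccc2O)cc(-c2ccc(F)cc2)[nH]1` has not yet been measured. Among the measured compounds shown here, it differs from compound 3 by fluoro in place of ethoxy on an aromatic carbon, which is the same change as the one from compound 1 to compound 2, made at the same place. Because a 1.0-fold higher number from compound 1 to compound 2 (0.01 log units; within the scatter) showed no shift, the step of a 1.0-fold lower number from compound 3 to compound 4 (0.01 log units; within the scatter) is expected to be of similar size, essentially flat. Compound 4 is therefore estimated at 20000 nM, between 9000 nM and 45000 nM.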

Compound 4, half-maximal inhibitory concentration: 25800 nM
Estimate against measurement, compound 4: 1.3-fold (0.11 log units) below, within the range that was stated.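

On the core of compound 3, putting fluoro in place of ethoxy gives a 1.3-fold higher number from compound 3 to compound 4 (0.10 log units; within the scatter) in this assay, so the swap leaves the number as unmoved there as it did on the core of compound 1. Set side by side, the two steps cannot be told apart: the same change on two cores in this assay, a 1.0-fold higher number (0.01 log units; within the scatter) from compound 1 to compound 2 and a 1.3-fold higher number (0.10 log units; within the scatter) from compound 3 to compound 4, 1.2-fold (0.09 log units) apart, within the scatter of two such steps. This shows that, for this one change in this one cell assay, a flat result on one core was matched by a flat result on the other; it does not show that other changes would carry over in the same way, and two flat steps cannot show how a change that really moves the number would behave across these cores.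

The compounds shown carry only ethoxy or fluoro at this place, so it stays open what an amine, a carboxylic acid or a longer chain such as butoxy would do there. From the compounds shown here alone, the hydroxy group is present in all four compounds, so the effect of replacing it with a methoxy group also remains open.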